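The source may hold more compounds than are shown below. What is called first, only, known or untested is meant among the compounds shown, and "the series" means these compounds.

Of the compounds shown here, three have been measured in a functional assay (spleen, spleen) for activation, with Mus musculus as the target; on this read-out higher numbers stand for an effect only at larger amounts of compound and lower numbers for an effect already at smaller amounts.

Compound 1 `CNc1nc(N)c2nc(O)n(Cc3ccccc3)c2n1` gives 1 uM.
Compound 2 `Nc1nc(SCc2ccccc2)nc2c1nc(O)n2Cc1ccccc1` gives 0.1 uM.
Compound 3 `CCNc1nc(N)c2nc(O)n(Cc3ccccc3)c2n1` gives 1 uM.

Compound 3 stands level with compound 1; together they carry the highest numbers of the three, and the only gap beyond the scatter is a 10-fold higher number from compound 2 to compound 3 (1.00 log units; beyond the scatter). Compound 4 `CCCOc1nc(N)c2nc(O)n(Cc3ccccc3)c2n1` is not yet measured. Its change from compound 3 is propoxy in place of ethylamino on an aromatic carbon. Among the compounds with values here, two measured steps bear on it: no change at the digits printed from compound 1 to compound 3 (within the scatter) shows that a longer chain at this carbon changes nothing, while a 10-fold lower number from compound 1 to compound 2 (1.00 log units; beyond the scatter) shows a lower number when the methylamino is exchanged for a benzylsulfanyl, a group that carries a ring, which propoxy does not. On this basis, for compound 4 no step beyond the scatter is expected, no change at the digits printed from compound 3 to compound 4 (within the scatter). Compound 4 is estimated at 1 uM, within 0.3 uM to 3 uM.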

Compound 4, minimum effective concentration: 0.01 uM
Estimate against measurement, compound 4: 100-fold (2.00 log units) above, and the stated range ends above it.
By their numbers in this assay, from the lowest: compound 4; then compound 2; then compounds 1 and 3 (each within the scatter of the next).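

Read in this assay the aromatic carbon between two ring nitrogen atoms proves far more responsive than the alkylamino pair suggested, with propoxy giving a large step against ethylamino (a 100-fold lower number from compound 3 to compound 4 (2.00 log units; beyond the scatter)) and against methylamino (a 100-fold lower number from compound 1 to compound 4 (2.00 log units; beyond the scatter)). Propoxy also passes benzylsulfanyl (a 10-fold lower number from compound 2 to compound 4 (1.00 log units; beyond the scatter)), so a ring in this group is not needed for the lowest number of the four. No measurement here explains the gain. Propoxy differs from ethylamino in both its linking atom and its chain, so ethoxy and propylamino remain the open comparisons for telling these apart.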